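From hydroxy to 2-aminophenyl on an amide-type nitrogen

The source may hold more compounds than are shown below. What is called first, only, known or untested is meant among the compounds shown, and "the series" means these compounds.

Measured in a functional assay on A549 cells (Homo sapiens) for antiproliferative activity, read by MTT assay, with a stated time of 72 h; a lower number here means a stronger inhibitor, a higher number a weaker inhibitor:
Compound 1 `O=C(CCCCCCc1nc(-c2ccc(C(F)(F)F)cc2)no1)NO`: 14000 nM
Compound 2 `O=C(CCCCCCc1nc(-c2cccc([N+](=O)[O-])c2)no1)NO`: 10800 nM

Within the data shown here, only these two compounds have numbers so far. Compound 2 gives the lower of the two numbers, but the gap to compound 1 lies within the scatter of repeated measurements, so the pair cannot be ranked. Both sit in the same region of this assay.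

Compound 3 `Nc1ccccc1NC(=O)CCCCCCc1nc(-c2cccc([N+](=O)[O-])c2)no1` has not yet been measured. It keeps everything in compound 2 except one group, carrying 2-aminophenyl in place of hydroxy on an amide-type nitrogen. Among the measured compounds shown here, no measured pair shows this change, so the data offer no direct guide to its size.

The expectation therefore starts from compound 2 at 10800 nM and is held loosely. A modest move towards a higher number is expected in this assay, one that may well not clear the scatter. The estimated change is a 1.4-fold higher number from compound 2 to compound 3 (0.14 log units; within the scatter). For compound 3 the expected value is 15000 nM, with an estimated range from 4000 nM to 50000 nM.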

Compound 3, half-maximal inhibitory concentration: 20200 nM
For compound 3 the middle estimate is 1.3-fold (0.13 log units) below the measured one; the range from low to high includes it.
By their numbers in this assay, from the lowest: compounds 2, 1 and 3 (each within the scatter of the next).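

In this assay, the change from hydroxy to 2-aminophenyl on the amide-type nitrogen gives a 1.9-fold higher number from compound 2 to compound 3 (0.27 log units; within the scatter), so this large exchange, from a single oxygen to a group of seven heavy atoms with a six-membered aromatic ring, does not separate compound 3 from compound 2. Among these compounds, compounds 1 and 2 both carry the hydroxycarbamoyl end and could say nothing about this position; compound 3 is the first to show that, with the rest of compound 2 held fixed, (2-aminophenyl)carbamoyl in place of hydroxycarbamoyl leaves the number in the same region of this assay. Nothing available here bears on why the two ends read so alike in these cells.

The compounds shown leave open whether the same exchange would read alike on compound 1, with its trifluoromethyl group in place of the nitro group, since only one such pair is at hand. They also leave open how other ends on this chain would read, such as a carboxylic acid or an unsubstituted phenyl amide, and whether a longer chain would change the picture for either end.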